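Dichloroacetanilides: trifluoromethyl in place of methoxy

This account rests on a few compounds, and the source may have more. Where it says the series, first, only, none or still open, it means among the compounds named here.

Compound 1 `O=C(Nc1ccccc1)C(Cl)Cl` is the shared core; in a functional assay on KB cells (Homo sapiens) for antiproliferative activity, read by MTT assay, with a stated time of 72 h (a lower number here means a stronger inhibitor, a higher number a weaker inhibitor), compound 1 stands as "not determined" (no result reported), so no number is available for it. Compound 2 `O=C(Nc1cccc([N+](=O)[O-])c1)C(Cl)Cl` gives 44700 nM in this assay. Compound 3 `COc1cccc(NC(=O)C(Cl)Cl)c1` gives 57700 nM in this assay, the higher of the two numbers available, with compound 2 nearest, and the two lie within the scatter of each other. Compound 4 `O=C(Nc1cccc(C(F)(F)F)c1)C(Cl)Cl` differs from compound 3 by trifluoromethyl in place of methoxy on an aromatic carbon. Going by the values given here, the one measured step that bears on this change is a 1.3-fold higher number from compound 2 to compound 3 (0.11 log units; within the scatter), which also exchanged the group on that aromatic carbon. A similarly small step is therefore expected in this assay, with no direction beyond the scatter. For compound 4 the expected step is a 1.2-fold lower number from compound 3 to compound 4 (0.06 log units; within the scatter). Compound 4 is estimated at 50000 nM, within 20000 nM to 120000 nM.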

Compound 4, half-maximal inhibitory concentration: 8860 nM
Estimate against measurement, compound 4: 5.6-fold (0.75 log units) above, outside the stated range (below it).
By their numbers in this assay, from the lowest: compound 4; then compounds 2 and 3 (each within the scatter of the next).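

In this assay, the group on this aromatic carbon can shift the number beyond the scatter: trifluoromethyl in place of methoxy gives a 6.5-fold lower number from compound 3 to compound 4 (0.81 log units; beyond the scatter), and trifluoromethyl in place of nitro gives a 5.0-fold lower number from compound 2 to compound 4 (0.70 log units; beyond the scatter). Methoxy and nitro alone had not revealed this, since their values lie within the scatter of each other. Nothing measured here explains the difference.

Going by these compounds, how an amine, a carboxylic acid or a longer chain on this carbon would compare remains open. Compound 1 gives "not determined" (no result reported), so the shared core offers no baseline for any of these groups.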